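Changing one aryl group on a sulfonamide nitrogen

This account rests on a few compounds, and the source may have more. Where it says the series, first, only, none or still open, it means among the compounds named here.

In a functional assay on MCF7 cells (Homo sapiens) for antiproliferative activity, read by MTT assay, with a stated time of 72 h (on this read-out lower numbers stand for stronger inhibition and higher numbers for weaker inhibition), compound 1 `CN(c1ccc(Cl)cc1)S(=O)(=O)C1CC2OC1C(c1ccc(NC(=O)CCCCCCC(=O)O)cc1)=C2c1ccc(O)cc1` gives 13700 nM and compound 2 `CCN(c1cccc(C)c1)S(=O)(=O)C1CC2OC1C(c1ccc(NC(=O)CCCCCCC(=O)O)cc1)=C2c1ccc(O)cc1` gives 31800 nM, so compound 2 holds the higher, weaker number of the pair. Compound 3 `CCN(c1ccc(O)cc1)S(=O)(=O)C1CC2OC1C(c1ccc(NC(=O)CCCCCCC(=O)O)cc1)=C2c1ccc(O)cc1` differs from compound 2 in one place, with 4-hydroxyphenyl in place of 3-methylphenyl on a sulfonamide nitrogen. Within the data shown here, the only measured step that changes groups on this nitrogen is a 2.3-fold higher number from compound 1 to compound 2 (0.37 log units; beyond the scatter), a modest one. Among the measured compounds shown here, no measured compound carries 4-hydroxyphenyl, so this single step is thin evidence. For the measured compounds named here, compound 1, at 13700 nM, shows only that a lower number is reachable with a different group here. In this assay, the expected change is similarly modest and leans toward a lower number, an estimated 1.6-fold lower number from compound 2 to compound 3 (0.20 log units; within the scatter). For compound 3 the estimated value is 20000 nM, within a range of 8000 nM to 45000 nM.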

Compound 3, half-maximal inhibitory concentration: 46600 nM
Compound 3: the middle estimate sits 2.3-fold (0.37 log units) below what was measured; the measured number lies above the stated range.
By their numbers in this assay, from the lowest: compound 1; then compounds 2 and 3 (each within the scatter of the next).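

With 4-hydroxyphenyl on the sulfonamide nitrogen, this assay gives a 1.5-fold higher number from compound 2 to compound 3 (0.17 log units; within the scatter) and so does not separate the two compounds, even though this group carries a hydrogen-bond donor and acceptor that 3-methylphenyl lacks. The larger change on the sulfonyl sulfur gives a 3.4-fold higher number from compound 1 to compound 3 (0.53 log units; beyond the scatter) and places compound 3 clearly apart from compound 1, but this step swaps the methyl for an ethyl as well as changing the aryl group, so it cannot be assigned to either part. No measurement shown here offers an explanation for these results.

The compounds shown leave open how much of the gap to compound 1 comes from 4-chlorophenyl and how much from the methyl on the nitrogen. They also leave open how 4-aminophenyl, or a carboxylic acid on the aryl ring, would read at this position.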